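Butyl chain on a fluorinated amidine core: expected half-life

The source may report more compounds than this note shows. Statements on the series, on what has been measured and on what is new or still open speak of the compounds shown alone.

Measured compounds:
Compound 1, `CC(NC(=O)c1ccc(C(=N)N)cc1)C(C)(C)C(=O)N1CCC(CC(=O)O)CC1`, in an in vivo ADME assay on the whole organism (Cavia porcellus) (a lower number here means that the compound disappears faster, a higher number that the compound lasts longer), gives 0.883 h.
Compound 2, `CCCC(NC(=O)c1ccc(C(=N)N)cc1)C(C)(C)C(=O)N1CCC(CC(=O)O)CC1`, in this assay gives 0.9 h.
Compound 3, `CCC(NC(=O)c1ccc(C(=N)N)cc1F)C(C)(C)C(=O)N1CCC(CC(=O)O)CC1`, in this assay gives 1.48 h.

Compound 2 differs from compound 1 by ethyl in place of hydrogen on a saturated chain carbon, two bonds along the chain from an amide-type nitrogen. That change produced a 1.0-fold higher number from compound 1 to compound 2 (0.01 log units; within the scatter). Compound 3 carries a different core; the difference between the core of compound 3 and the core of compound 1 is not broken down here. The values of compound 3, compound 2 and compound 1 all lie within the usual scatter of one another, so no order can be read among them.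

Compound 4, `CCCCC(NC(=O)c1ccc(C(=N)N)cc1F)C(C)(C)C(=O)N1CCC(CC(=O)O)CC1`, has not been measured. It differs from compound 3 by ethyl in place of hydrogen on a saturated chain carbon, three bonds along the chain from an amide-type nitrogen. Among the measured compounds shown here, this is the same kind of change as the one from compound 1 to compound 2, but the place is not the same: there the ethyl entered two bonds along the chain from an amide-type nitrogen, here it enters three bonds along the chain from that nitrogen. The expected step is a 1.0-fold higher number from compound 3 to compound 4 (0.01 log units; within the scatter), resting on the earlier 1.0-fold higher number from compound 1 to compound 2 (0.01 log units; within the scatter), which left the number essentially unchanged. Compound 4 is therefore estimated at 1.5 h, between 0.8 h and 2.8 h.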

Compound 4, half-life: 1.3 h
The estimate for compound 4 lay 1.2-fold (0.06 log units) above the measured number; the range from low to high includes it.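

The new step in this assay is a 1.1-fold lower number from compound 3 to compound 4 (0.06 log units; within the scatter), so these two numbers cannot be told apart. Set beside the earlier step, adding an ethyl to the chain gives the same outcome on both cores, and nothing here suggests that the core alters it: the same change on two cores in this assay, a 1.0-fold higher number (0.01 log units; within the scatter) from compound 1 to compound 2 and a 1.1-fold lower number (0.06 log units; within the scatter) from compound 3 to compound 4, 1.2-fold (0.06 log units) apart, within the scatter of two such steps. Among the compounds shown here, this shows only that the swap, methyl to propyl in one pair and ethyl to butyl in the other, had no readable effect on half-life in either; it does not rule out a small effect hidden inside the scatter, and two cores say nothing about how the swap would behave on a third.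

Still open, going by these compounds, is whether any other group on this chain could move the half-life beyond the scatter, such as a longer chain like hexyl, a ring like cyclohexyl, or a chain ending in an amine or a hydroxyl group. Also open is whether a chain of a length not shown here would follow the same flat pattern on both cores.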